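The compounds below may be only part of what the source reports. "The series", "measured", "known", "first", "only" and "open" are said of these compounds alone.

Compound 2 `O=C(/C=C/c1cc2ccccc2[nH]c1=O)c1ccc(O)cc1` gives only a limit in an ADME assay on SF-268 cells (Homo sapiens) for cytotoxicity, read by sulforhodamine B assay, with a stated time of 24 h (a higher number here means that more compound is tolerated, a lower number that less compound is tolerated), namely > 100000 nM. Compound 1 `COc1ccc(C(=O)/C=C/c2cc3ccccc3[nH]c2=O)cc1` gives 40700 nM in this assay. The step of an at least 2.4-fold higher number from compound 1 to compound 2 (0.39 log units; beyond the scatter) ends at the limit of > 100000 nM in this assay, at which 1 of the 2 values shown sits, so compound 2 stands at the upper edge of the numbers shown. Compound 3 `O=C(/C=C/c1cc2ccccc2[nH]c1=O)c1ccc(Cl)cc1` differs from compound 2 by chloro in place of hydroxy on an aromatic carbon. Among the compounds with values here, no measured step carries this change; the one measured step exchanged methyl for hydrogen on an oxygen and was modest, so a step of an at least 1.6-fold lower number from compound 2 to compound 3 (0.22 log units; that floor lies within the scatter) of comparable modest size is expected, direction uncertain. Compound 3 is therefore expected to give 60000 nM in this assay, between 25000 nM and 150000 nM.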

Compound 3, concentration lethal to 50% of the cells: > 100000 nM
Compound 3 was reported as a limit (the forecaster's own chance of this, stated with the estimate: 40%); middle value at least 1.6-fold (0.22 log units) from the limit.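

Chloro in place of methoxy gives an at least 2.4-fold higher number from compound 1 to compound 3 (0.39 log units; beyond the scatter) in this assay, so a group with no hydrogen-bond donor at this position also ends higher than methoxy. Compound 2 and compound 3 are both limits, and the step between them cannot be read. Of the three groups at this position, only methoxy gives a number short of the limit, and the other two share it: the limit of > 100000 nM in this assay, at which 2 of the 3 values shown sit.

Going by these compounds, whether an amine, a carboxylic acid or a longer chain such as ethoxy at this position stays at that limit or falls towards compound 1 remains open. On these data alone, whether hydroxy and chloro differ at all also remains open.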